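The compounds below may be only part of what the source reports. "The series", "measured", "known", "first", "only" and "open" are said of these compounds alone.

Measured so far in a functional assay on A549 cells (Homo sapiens) for cytotoxicity, read by MTT assay, with a stated time of 72 h; a higher number here means a weaker inhibitor, a lower number a stronger inhibitor:
- compound 1 `COc1ccc(-n2ccc(=O)c(C(=O)Nc3ccc(Oc4ccnc5[nH]ccc45)cc3)n2)cc1` gives 53100 nM
- compound 2 `O=C(Nc1ccc(Oc2ccnc3[nH]ccc23)cc1)c1nn(-c2ccccc2)ccc1=O` gives 10500 nM
- compound 3 `O=C(Nc1ccc(Oc2ccnc3[nH]ccc23)cc1)c1nn(-c2ccc(Cl)c(F)c2)ccc1=O` gives 2580 nM

Compound 3 stands lowest of the three, which means it is the strongest inhibitor seen so far. Both steps leading to it are beyond the scatter: a 4.1-fold lower number from compound 2 to compound 3 (0.61 log units; beyond the scatter) and a 21-fold lower number from compound 1 to compound 3 (1.31 log units; beyond the scatter), the latter being the larger of the two. The step of a 5.1-fold lower number from compound 1 to compound 2 (0.70 log units; beyond the scatter) is also beyond the scatter and points the same way.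

Compound 4 `O=C(Nc1ccc(Oc2ccnc3[nH]ccc23)cc1)c1nn(-c2ccc(Cl)c(C(F)(F)F)c2)ccc1=O` differs from compound 3 in one place: trifluoromethyl in place of fluoro on an aromatic carbon. For the measured compounds named here, no measured step changes only this group. The closest comparison is a 4.1-fold lower number from compound 2 to compound 3 (0.61 log units; beyond the scatter), where the chloro and fluoro groups arrived together on the ring attached to the aromatic nitrogen, and that step was modest. Since the fluoro was only part of that change, swapping it for trifluoromethyl is expected to move this assay little, if at all beyond the scatter; the expected step of a 1.3-fold lower number from compound 3 to compound 4 (0.11 log units; within the scatter) is therefore small, with the direction uncertain. Compound 4 is estimated at 2000 nM, with a range from 600 nM to 7000 nM.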

Compound 4, half-maximal inhibitory concentration: 2190 nM
Beside the measured number, compound 4's estimate is 1.1-fold (0.04 log units) below it; the range from low to high includes it.
By their numbers in this assay, from the lowest: compounds 4 and 3 (each within the scatter of the next); then compound 2; then compound 1.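

In this assay, the step of a 1.2-fold lower number from compound 3 to compound 4 (0.07 log units; within the scatter) shows that this position, ortho to a chloro group, can hold trifluoromethyl, with 4 heavy atoms, in place of fluoro, with 1, without a change beyond the scatter. The larger group also keeps the gain seen with the 4-chloro-3-fluorophenyl ring: the step of a 4.8-fold lower number from compound 2 to compound 4 (0.68 log units; beyond the scatter) starts from the plain phenyl ring, and the step of a 24-fold lower number from compound 1 to compound 4 (1.38 log units; beyond the scatter) starts from the 4-methoxyphenyl ring. No measurement offered here accounts for fluoro and trifluoromethyl reading alike in these cells.

On these data alone, how much of the drop from compound 2 belongs to the chloro group, and how much to the fluoro or trifluoromethyl group, stays open, as these groups appear together in both compound 3 and compound 4. Also open, as far as these compounds go, is whether this position would accept a group of a different kind from these two, which count no hydrogen-bond donors or acceptors, such as an amine or a carboxylic acid.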